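The source may report more compounds than this note shows. Statements on the series, on what has been measured and on what is new or still open speak of the compounds shown alone.

Measured in a functional assay on B16-F10 cells (Mus musculus) for cytotoxicity; a lower number here means a stronger inhibitor, a higher number a weaker inhibitor:
Compound 1 `O=c1oc2ccccc2c2nc3c(ccc4cc[nH]c43)c(-c3cccnc3Cl)c12`: 70700 nM
Compound 2 `O=c1oc2ccccc2c2nc3c(ccc4cc[nH]c43)c(-c3ccc([N+](=O)[O-])cc3)c12`: 70700 nM

On these numbers, compound 2 has nothing to separate it from compound 1: the two values match at the digits shown. Compound 3 `Cc1ccc(-c2c3ccc4cc[nH]c4c3nc3c2c(=O)oc2ccccc23)cc1` keeps the shared core of compound 2 but carries methyl in place of nitro on an aromatic carbon, para to a large group (methyl in place of nitro on an aromatic carbon). Among the compounds with values here, only one measured step bears on this, no change at the digits printed from compound 1 to compound 2 (within the scatter), where 4-nitrophenyl took the place of 2-chloropyridin-3-yl. A single step is thin evidence, and it does not test nitro against methyl directly. Still, that swap of a whole group left the value unmoved, so no step beyond the scatter is expected in this assay, in either direction. The expected change is a 1.2-fold lower number from compound 2 to compound 3 (0.07 log units; within the scatter). Compound 3 is estimated at 60000 nM, with an expected range of 20000 nM to 100000 nM.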

Compound 3, half-maximal inhibitory concentration: 70700 nM
The estimate for compound 3 lay 1.2-fold (0.07 log units) below the measured number; the range from low to high includes it.
By their numbers in this assay, from the lowest: compounds 1, 2 and 3 (each within the scatter of the next).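

Replacing nitro by methyl on the aromatic carbon para to a large group gives no change at the digits printed from compound 2 to compound 3 (within the scatter) in this assay, so this pair tests the end group alone, with the rest of the 4-substituted phenyl kept. Comparing the 4-methylphenyl group with 2-chloropyridin-3-yl gives no change at the digits printed from compound 1 to compound 3 (within the scatter), which adds a third group at this place with a matching value and shows that neither nitro nor methyl separates from the chloropyridine here. Nothing available explains why the three values coincide.

From the compounds shown here alone, whether this flat picture holds for an amine, a carboxylic acid or a longer chain at the same place remains open. So does the effect of altering the shared core, which is identical in all three compounds.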